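Aryl swaps on the alkyne of the shared core

This account rests on a few compounds, and the source may have more. Where it says the series, first, only, none or still open, it means among the compounds named here.

compound 1 `CC(C)N1CCc2nc(C#Cc3cccc(Cl)c3)ccc2C1=O`: 100 nM
compound 2 `O=C1c2ccc(C#Cc3ccccc3)nc2CCN1C1CCCC1`: 890 nM
compound 3 `Cc1ccc(C#Cc2ccc3c(n2)CCN(C2CCCC2)C3=O)cc1`: > 32000 nM
compound 4 `O=C1c2ccc(C#Cc3cccc(Cl)c3)nc2CCN1C1CCCC1`: not yet measured

In an assay on HEK293 cells for displacement of a labelled ligand from metabotropic glutamate receptor 5 (Homo sapiens), with a stated time of 2 h (on this read-out higher numbers stand for weaker inhibition and lower numbers for stronger inhibition), compound 1 gives 100 nM and compound 2 gives 890 nM. For compound 3 the read-out is only a limit of the assay, > 32000 nM, namely (the limit of > 32000 nM in this assay, at which 1 of the 3 values shown sits). Compound 3 therefore stands at the weak end of the set. The next change is 3-chlorophenyl in place of 4-methylphenyl on a triple-bonded carbon. It reverses the change behind an at least 35-fold higher number from compound 2 to compound 3 (1.55 log units; beyond the scatter) and installs the aryl that compound 1 carries, and compound 1 gives 100 nM in this assay. Compound 4 is therefore expected to show a large fall in the number, an at least 80-fold lower number from compound 3 to compound 4 (1.90 log units; beyond the scatter). Compound 4 is estimated at 400 nM, within 100 nM to 2000 nM.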

Compound 4, inhibition constant: 5230 nM
For compound 4 the middle estimate is 13-fold (1.12 log units) below the measured one; measured number above the stated range.
By their numbers in this assay, from the lowest: compound 1; then compound 2; then compound 4. At a limit, above all of these: compound 3.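

The 3-chlorophenyl on the triple-bonded carbon gives a better result than 4-methylphenyl (an at least 6.1-fold lower number from compound 3 to compound 4 (0.78 log units; beyond the scatter)), yet this step is only a bound, as compound 3 stands at a limit of the assay: the limit of > 32000 nM in this assay, at which 1 of the 4 values shown sits.
With cyclopentyl on the nitrogen, the added chloro of the 3-chlorophenyl weakens rather than strengthens inhibition (a 5.9-fold higher number from compound 2 to compound 4 (0.77 log units; beyond the scatter)). With the 3-chlorophenyl held constant, the choice of group on the amide-type nitrogen matters more (a 52-fold higher number from compound 1 to compound 4 (1.72 log units; beyond the scatter)).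
Open, as far as these compounds go, is how an aryl bearing an amine or a carboxylic acid would behave on the triple-bonded carbon. Also open, from the compounds shown here alone, is how a longer chain would behave on the amide-type nitrogen.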